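Swapping methoxy for nitro on a shared core

The source may hold more compounds than are shown below. What is called first, only, known or untested is meant among the compounds shown, and "the series" means these compounds.

Compound 1, `S=C(NCc1cccnc1)SCCc1nnn[nH]1`, in a functional assay on SK-BR-3 cells (Homo sapiens) for cytotoxicity, read by resazurin assay, with a stated time of 72 h; on this read-out higher numbers stand for weaker inhibition and lower numbers for stronger inhibition: > 100000 nM (a limit of the assay).
Compound 2, `S=C(NCc1cccnc1)SCCc1nc2ccccc2o1`: 820 nM.
Compound 3, `COc1ccc(-c2nnc(CCSC(=S)NCc3cccnc3)o2)cc1`: 2960 nM.

Compound 1 reaches only a limit of the assay, not a number. Of the two numbers, compound 3 stands highest, meaning weaker inhibition, and compound 2 sits beyond the usual scatter below it. Compound 4, `O=[N+]([O-])c1ccc(-c2nnc(CCSC(=S)NCc3cccnc3)o2)cc1`, differs from compound 3 by nitro in place of methoxy on an aromatic carbon. Going by the values given here, no measured pair shows this change, so the expected step from compound 3 to compound 4 a 1.2-fold lower number from compound 3 to compound 4 (0.07 log units; within the scatter) is set at none beyond the scatter. Compound 4 is therefore estimated at 2500 nM, with a likely range from 800 nM to 8000 nM.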

Compound 4, half-maximal inhibitory concentration: 1540 nM
Beside the measured number, compound 4's estimate is 1.6-fold (0.21 log units) above it, within the range that was stated.
By their numbers in this assay, from the lowest: compounds 2, 4 and 3 (each within the scatter of the next, the first and the last beyond it). At a limit, above all of these: compound 1.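

Going from 4-methoxyphenyl to 4-nitrophenyl gives the first direct reading at this position: in this assay the change is a 1.9-fold lower number from compound 3 to compound 4 (0.28 log units; within the scatter) on the shared core. Nitro in place of methoxy therefore leaves the number indistinguishable from that of the starting compound, even though the two groups differ in their atoms. Nothing measured here bears on the cause of this result. From the compounds shown here alone, whether an amine or a carboxylic acid on this aromatic carbon would also leave the number unchanged remains open, as does the effect of a plain hydrogen there.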